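Ester to Amide Swap on a Cyanoguanidine Antagonist

A few compounds are considered here, and "the series" means these few. Any claim that something is new, unique, unknown or untested is made for them only; others in the source may bear on it.

Among the compounds with values here, compound 1, `N#CN/C(=N\CCOC(=O)c1ccccc1)NCCCOc1cccc(CN2CCCCC2)c1`, gives 7.64 in a functional assay on cardiac atrium for antagonist activity at histamine H2 receptor (Cavia porcellus) (a higher number here means a more potent compound, by a factor of ten per unit of this negative logarithm, a lower number a less potent compound), the higher of the two numbers known so far. Compound 2, `N#CN/C(=N\CCCNc1ccc(N=[N+]=[N-])cc1[N+](=O)[O-])NCCCCOc1cccc(CN2CCCCC2)c1`, gives 6.56, beyond the scatter below compound 1. Compound 3, `N#CN/C(=N\CCNC(=O)CCCc1ccccc1)NCCCOc1cccc(CN2CCCCC2)c1`, differs from compound 1 by ((3-phenylpropyl)carbonyl)amino in place of benzoyloxy on a saturated chain carbon, two bonds along the chain from a double-bonded nitrogen. Within the data shown here, no measured pair shows this change, so the direction is uncertain; a small loss, within or just beyond the scatter, is expected for the step of a number 0.34 log units lower from compound 1 to compound 3 (beyond the scatter). Compound 3 is therefore estimated at 7.3, with a range from 6.6 to 8.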

Compound 3, negative logarithm of the antagonist equilibrium constant: 6.45
The estimate for compound 3 lay 0.85 log units above the measured number, outside the stated range (below it).
By their numbers in this assay, from the lowest: compounds 3 and 2 (each within the scatter of the next); then compound 1.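

In this assay, putting ((3-phenylpropyl)carbonyl)amino in place of benzoyloxy gives a large loss, a number 1.19 log units lower from compound 1 to compound 3 (beyond the scatter). This position is therefore sensitive to the group it carries, even though both groups hold one six-membered aromatic ring of carbon only. Nothing available explains why the number falls. The compounds shown leave open whether the loss goes with the amide link or with the longer chain. A benzoylamino group at this place, or a 3-phenylpropyl chain joined through an ester, would separate the two.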